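The compounds below may be only part of what the source reports. "The series", "measured", "known", "first", "only" and "open" are said of these compounds alone.

Compound 1, `COc1ccc(-c2cc3ccccc3nc2/C=C/C(=O)c2ccccc2)cc1`, gives 1410 nM in a functional assay on NCI-H1299 cells (Homo sapiens) for antiproliferative activity, read by XTT assay, with a stated time of 72 h; on this read-out lower numbers stand for stronger inhibition and higher numbers for weaker inhibition.
Compound 2, `COc1ccc(-c2cc3ccccc3nc2/C=C/C(=O)c2c(OC)cccc2OC)cc1`, gives 4710 nM.
Compound 3, `COc1ccc(-c2cc3ccccc3nc2/C=C/C(=O)c2ccc(OC)c(OC)c2)cc1`, gives 1050 nM.

On these numbers compound 2 stands highest, the weakest of the three, and its steps to both others lie beyond the scatter. Compound 4, `COc1ccc(-c2cc3ccccc3nc2/C=C/C(=O)c2cnc(N)nc2C)cc1`, differs from compound 2 by 2-amino-4-methylpyrimidin-5-yl in place of 2,6-dimethoxyphenyl on a carbonyl carbon. Among the compounds with values here, two measured steps bear on this change, each removing the same group from the carbonyl carbon: a 3.3-fold higher number from compound 1 to compound 2 (0.52 log units; beyond the scatter), read in reverse, and a 4.5-fold lower number from compound 2 to compound 3 (0.65 log units; beyond the scatter). Both point to a lower number once the 2,6-dimethoxyphenyl is gone, though the entering group resembles neither replacement tried so far. A modest fall is therefore expected for compound 4, a 3.1-fold lower number from compound 2 to compound 4 (0.50 log units; beyond the scatter). Compound 4 is estimated at 1500 nM, within 500 nM to 4500 nM.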

Compound 4, half-maximal inhibitory concentration: > 10000 nM
Compound 4 was reported as a limit; the forecaster's own chance of this, stated with the estimate: 5%; middle value at least 6.6-fold (0.82 log units) away from the limit.
By their numbers in this assay, from the lowest: compounds 3 and 1 (each within the scatter of the next); then compound 2. At a limit, above all of these: compound 4.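

Compound 4 gives no number in this assay, only a limit: the limit of > 10000 nM in this assay, at which 1 of the 4 values shown sits. Placing 2-amino-4-methylpyrimidin-5-yl on the carbonyl carbon gives an at least 2.1-fold higher number from compound 2 to compound 4 (0.32 log units; beyond the scatter), an at least 7.0-fold higher number from compound 1 to compound 4 (0.85 log units; beyond the scatter) and an at least 9.5-fold higher number from compound 3 to compound 4 (0.97 log units; beyond the scatter). Losing the 2,6-dimethoxyphenyl therefore does not by itself lower the number, and this position tells these aromatic rings apart sharply, with the nitrogen-containing ring the weakest of the four.

As far as these compounds go, the ring nitrogens, the amine and the methyl enter together, so which of them matters stays open. An aminophenyl group or a plain pyridine ring at this position would help separate them.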